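Removing the cyclohexylamino group from compound 2

A few compounds are considered here, and "the series" means these few. Any claim that something is new, unique, unknown or untested is made for them only; others in the source may bear on it.

Measured compounds:
compound 1, `CN1CCN(c2ccc(NC(=N)c3cc4c(-c5ccccc5)n[nH]c4c(NC4CCCCC4)n3)cc2)CC1`, 12300 nM
compound 2, `COc1ccc(Cn2nc(-c3ccccc3)c3cc(C(=N)Nc4ccc(N5CCN(C)CC5)cc4)nc(NC4CCCCC4)c32)cc1`, 3330 nM

In an ADME assay on AG1523 cells (Homo sapiens) for cytotoxicity, read by MTT assay, with a stated time of 72 h (a higher number here means a weaker inhibitor, a lower number a stronger inhibitor), compound 2 stands with the lowest of the two numbers; compound 1 sits higher by a 3.7-fold lower number from compound 1 to compound 2 (0.57 log units; beyond the scatter). Compound 3, `COc1ccc(Cn2nc(-c3ccccc3)c3cc(C(=N)Nc4ccc(N5CCN(C)CC5)cc4)ncc32)cc1`, is not yet measured. It differs from compound 2 by hydrogen in place of cyclohexylamino on an aromatic carbon. Going by the values given here, the only measured step concerns a different position and a different group, so no measured step bears on this change. With nothing to anchor it, a step of no more than the scatter is expected, a 1.7-fold higher number from compound 2 to compound 3 (0.22 log units; within the scatter), leaning toward a slightly higher number. Compound 3 is therefore estimated at 5500 nM, within 1500 nM to 20000 nM.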

Compound 3, half-maximal inhibitory concentration: 10200 nM
Estimate against measurement, compound 3: 1.9-fold (0.27 log units) below; the measured number falls inside the stated range.
By their numbers in this assay, from the lowest: compound 2; then compounds 3 and 1 (each within the scatter of the next).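

Putting hydrogen in place of cyclohexylamino on the aromatic carbon next to the ring nitrogen gives a 3.1-fold higher number from compound 2 to compound 3 (0.49 log units; beyond the scatter) in this assay. Going by these compounds alone, this is the first sign that this position, and not only the aromatic nitrogen, bears on the number, and removing the group moves it towards weaker inhibition. Nothing available gives a reason for this shift. From the compounds shown here alone, whether a smaller amine such as methylamino, or an ether such as methoxy, would keep the lower number remains open. So does whether the step holds when the aromatic nitrogen carries hydrogen instead of 4-methoxybenzyl.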